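The source may hold more compounds than are shown below. What is called first, only, known or untested is meant among the compounds shown, and "the series" means these compounds.

Among the measured compounds shown here, in a functional assay on the whole organism with Mus musculus as the target (a lower number here means that less compound is needed, a higher number that more compound is needed for the effect), compound 2 `NC(=O)/C=C1\CCc2ccccc21` gives 108 mg/kg, the highest of the three numbers known here, though both partners sit within the usual scatter of it: compound 1 `NC(=O)/C=C1\CCc2c(F)cc(F)cc21` gives 69 mg/kg and compound 3 `NC(=O)/C=C1\CCc2ccc(F)cc21` gives 56 mg/kg. Compound 4 `NC(=O)/C=C1\CCc2c(F)cccc21` differs from compound 2 by fluoro in place of hydrogen on an aromatic carbon. For the measured compounds named here, two measured steps bear on this. The same kind of change, fluoro in place of hydrogen on an aromatic carbon, gave a 1.9-fold lower number from compound 2 to compound 3 (0.29 log units; within the scatter), and hydrogen in place of fluoro gave a 1.2-fold lower number from compound 1 to compound 3 (0.09 log units; within the scatter), so a single fluoro has so far shifted the number only within the scatter. Compound 4 is therefore expected to show a 1.4-fold lower number from compound 2 to compound 4 (0.13 log units; within the scatter), a small lowering at most. The estimate for compound 4 is 80 mg/kg, with a range from 45 mg/kg to 145 mg/kg.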

Compound 4, dose for half-maximal effect: > 100 mg/kg
Compound 4: a limit, no number; the forecaster's own chance of this, stated with the estimate: 3%; middle value at least 1.2-fold (0.09 log units) from the limit.
By their numbers in this assay, from the lowest: compounds 3, 1 and 2 (each within the scatter of the next).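

In this assay, compound 4, with its fluoro ortho to a fused ring, carries a limit, > 100 mg/kg, and not a number. Its step from compound 2 therefore cannot be read, so this position does not yet show the same behaviour as the fluoro of compound 3. Hydrogen in place of the other fluoro gives an at least 1.4-fold higher number from compound 1 to compound 4 (0.16 log units; that floor lies within the scatter), which is only a floor with no upper end. From the compounds shown here alone, how an amine or a methoxy group at this position would read in this assay stays open. Whether the change acts alike at both positions also stays open: the same change on two cores in this assay, a 1.9-fold lower number (0.29 log units; within the scatter) from compound 2 to compound 3 and an at least 1.4-fold lower number (0.16 log units; that floor lies within the scatter) from compound 4 to compound 1; the limit leaves it open whether they differ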